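The source may report more compounds than this note shows. Statements on the series, on what has been measured and on what is new or still open speak of the compounds shown alone.

Measured in a functional assay on U-373MG ATCC cells (Homo sapiens) for inhibition, read by MTT assay, with a stated time of 72 h; a lower number here means a stronger inhibitor, a higher number a weaker inhibitor:
- compound 1 `CC1(C)CC(NC(=O)Nc2cccc(Cl)c2)c2cc(Br)ccc2O1`: 69000 nM
- compound 2 `CC(C)NC(=S)NC1CC(C)(C)Oc2ccc(Cl)cc21`: 57000 nM
- compound 3 `CCNC(=S)NC1CC(C)(C)Oc2ccc(Cl)cc21`: 96000 nM

In this assay compound 1 gives 69000 nM. That number lies within the usual scatter of the values of both compound 2 and compound 3, so the three cannot be ranked, and all three sit in the same narrow band.

The next compound is compound 4 `CC1(C)CC(NC(=O)Nc2ccc(Cl)cc2)c2cc(Br)ccc2O1`, which has not yet been measured. It keeps the core of compound 1 and differs in one place: 4-chlorophenyl in place of 3-chlorophenyl on an amide-type nitrogen. In words, 4-chlorophenyl stands in place of 3-chlorophenyl on an amide-type nitrogen.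

Among the measured compounds shown here, only one measured step is available, a 1.7-fold higher number from compound 2 to compound 3 (0.23 log units; within the scatter). It concerns a different change in a different part of the structure, so it offers only indirect guidance, showing that one small edit in this set left the number within the scatter. For the measured compounds named here, no measured pair shows what this swap of 3-chlorophenyl for 4-chlorophenyl does, and the data favour neither direction.

The expected result is therefore a 1.2-fold lower number from compound 1 to compound 4 (0.06 log units; within the scatter), a step no larger than the scatter. For compound 4 the estimated value is 60000 nM, with an expected range from 25000 nM to 120000 nM.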

Compound 4, half-maximal inhibitory concentration: 25000 nM
Beside the measured number, compound 4's estimate is 2.4-fold (0.38 log units) above it; the range from low to high includes it.
By their numbers in this assay, from the lowest: compound 4; then compounds 2, 1 and 3 (each within the scatter of the next).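

Among the compounds shown here, exchanging 3-chlorophenyl for 4-chlorophenyl on the amide-type nitrogen gives a 2.8-fold lower number from compound 1 to compound 4 (0.44 log units; beyond the scatter) in this assay, and this is the first step in the set that clears the scatter. The two groups hold the same atoms and differ only in how they are joined, so this one pair shows that the number can respond to where the chlorine sits on the phenyl ring, even though no atom is added or removed and the step is only modest. No measurement is available that explains this difference.

A single pair cannot say whether other groups on this nitrogen, such as a plain phenyl or a pyridine ring, would lower the number further, raise it again or leave it where it is. The compounds shown also leave open whether the same swap would have a similar effect with chlorine in place of the bromine on the shared core, or with a thiocarbonyl in place of the carbonyl.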